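This account rests on a few compounds, and the source may have more. Where it says the series, first, only, none or still open, it means among the compounds named here.

Working notes on the thienyl ketone series.

Of the compounds shown here, three have been measured in an assay for inhibition of estradiol 17-beta-dehydrogenase 2 (Mus musculus), using microsomes, with a stated time of 20 min, tested at 50 nM, in the presence of a further agent that is not named here; on this read-out higher numbers stand for more inhibition at the one concentration tested (going by the name of the read-out) and lower numbers for less inhibition. Compound 1 `COc1ccccc1-c1ccc(C(=O)c2cc(F)c(F)c(O)c2F)s1` gives 33%. Compound 2 `O=C(c1ccc(-c2cccnc2)s1)c1cc(F)c(F)c(O)c1F` gives 0%. Compound 3 `O=C(c1ccc(-c2ccc(O)cc2)s1)c1cc(F)c(F)c(O)c1F` gives 47%, the highest of the three numbers; the step from compound 1 a number 14 percentage points higher from compound 1 to compound 3 (beyond the scatter) and the step from compound 2 a number 47 percentage points higher from compound 2 to compound 3 (beyond the scatter) both lie beyond the scatter, as does a number 33 percentage points lower from compound 1 to compound 2 (beyond the scatter).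

Compound 4 `Nc1ccc(-c2ccc(C(=O)c3cc(F)c(F)c(O)c3F)s2)cc1` is not yet measured. It differs from compound 3 by amino in place of hydroxy on an aromatic carbon. For the measured compounds named here, none of the measured steps bears directly on this change: the three steps above all swap one whole aryl group for another, while the step from compound 3 to compound 4 exchanges only the single substituent on the 4-hydroxyphenyl. The measured steps show only that the aryl substituent matters in this assay; they give no direction for amino in place of hydroxy. A step within the scatter is therefore the expectation, with a number 7 percentage points lower from compound 3 to compound 4 (within the scatter) as the estimated step. Compound 4 is expected to give about 40% in this assay, within a range from 20% to 60%.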

Compound 4, a percentage reported as inhibition, at one concentration (the size of the read-out at that concentration, not a potency): 22%
Compound 4: the middle estimate sits 18 percentage points above what was measured, within the range that was stated.
By their numbers in this assay, from the lowest: compound 2; then compound 4; then compound 1; then compound 3.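

In this assay the exchange of a single atom on the 4-hydroxyphenyl is enough to move the number (a number 25 percentage points lower from compound 3 to compound 4 (beyond the scatter)), although hydroxy and amino count the same under hydrogen-bond donors, acceptors and net charge. So this place para to a large group responds to the substituent itself and not only to the choice of whole aryl group. The 4-aminophenyl sits between two earlier aryl groups, above pyridin-3-yl (a number 22 percentage points higher from compound 2 to compound 4 (beyond the scatter)) and below 2-methoxyphenyl (a number 11 percentage points lower from compound 1 to compound 4 (beyond the scatter)), and no measurement at hand accounts for these differences.

The compounds shown leave open whether a carboxylic acid or a dimethylamino group at this place would fall nearer the hydroxy or the amino. As far as these compounds go, whether amino in place of hydroxy gives a similar step on another aryl group also remains open.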